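Adding a sugar-like group to the ring nitrogen of compound 2

This account rests on a few compounds, and the source may have more. Where it says the series, first, only, none or still open, it means among the compounds named here.

Compound 2 `COc1c(C)cnc(CNc2ccc3[nH]c(C)nc3c2)c1C` stands lowest of the two measured compounds: in a functional assay on the whole organism (strain Sprague-Dawley) for inhibition, with Rattus norvegicus as the target, read by paw edema, with a stated time of 180 min, at a dose of 10 mg/kg by the oral route (a lower number here means a weaker effect, a higher number a stronger effect of the compound at the dose given), compound 2 gives 10%, whereas compound 1 `COc1ccnc(CNc2ccc3c(c2)nc(C)n3C[C@@H](O)[C@H]2O[C@H](O)[C@@H](O)[C@H]2O)c1OC`, which carries a larger group on its ring nitrogen, gives 41% in this assay, a gap beyond the scatter. Compound 3 `COc1c(C)cnc(CNc2ccc3c(c2)nc(C)n3C[C@@H](O)[C@H]2O[C@H](O)[C@@H](O)[C@H]2O)c1C` is compound 2 changed by a group of 11 heavy atoms (6 carbon, 5 oxygen; one five-membered non-aromatic ring with 1 hetero atom) in place of a hydrogen atom, on an aromatic nitrogen. Given that compound 1 with such a group gives 41%, the step is expected to raise inhibition by a number 25 percentage points higher from compound 2 to compound 3 (beyond the scatter) in this assay. Compound 3 is therefore estimated at 35%, within 15% to 55%.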

Compound 3, a percentage reported as inhibition, in the whole organism at one dose (the size of the read-out at that dose, not a potency): 36%
For compound 3 the middle estimate is 1 percentage points below the measured one, and the stated range covers the measured number.
By their numbers in this assay, from the lowest: compound 2; then compounds 3 and 1 (each within the scatter of the next).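

Placing this group on the aromatic nitrogen gives, in this assay, a number 26 percentage points higher from compound 2 to compound 3 (beyond the scatter), so the gain now rests on a comparison that differs in one place. Having 4-methoxy-3,5-dimethylpyridin-2-yl in place of 3,4-dimethoxypyridin-2-yl gives a number 5 percentage points lower from compound 1 to compound 3 (within the scatter), so the two groups are not told apart here. Nothing available accounts for the gain. The compounds shown leave open whether the whole group is needed on this nitrogen, or whether a simple hydroxyethyl chain or a carboxylic acid there would give a similar inhibition.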